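This account rests on a few compounds, and the source may have more. Where it says the series, first, only, none or still open, it means among the compounds named here.

The measured compounds:

Compound 1, `Cc1ccc2nc(N3CCCc4ccc(F)cc4C3)cc(NCCN)c2c1`: in an ADME assay on HEp-2 cells (Homo sapiens) for cytotoxicity, read by CCK-8 assay, with a stated time of 5 days (on this read-out lower numbers stand for higher toxicity in this test and higher numbers for lower toxicity in this test), compound 1 reports only a limit of the assay, > 3200 nM.

Compound 2, `Cc1ccc2nc(N3CCCc4ccc(F)cc4C3)cc(NC(C)CN)c2c1`: in this assay compound 2 gives 25000 nM.

Compound 3, `CC(=O)NCCNc1cc(N2CCCc3ccc(F)cc3C2)nc2ccc(C)cc12`: in this assay compound 3 gives 66000 nM.

Of the two plain numbers, compound 3 holds the higher one; its nearest neighbour is compound 2, and the step of a 2.6-fold higher number from compound 2 to compound 3 (0.42 log units; beyond the scatter) lies beyond the scatter. Compound 4, `Cc1ccc2nc(N3CCCc4ccc(F)cc4C3)cc(NCCO)c2c1`, is not yet measured. It differs from compound 3 by hydroxy in place of acetamido on a saturated chain carbon, two bonds along the chain from a nitrogen on an aromatic ring. For the measured compounds named here, two measured steps touch this part of the molecule. The step that the limit leaves unreadable from compound 1 to compound 3 adds an acetyl on the amine nitrogen, and its size cannot be read. The step of a 2.6-fold higher number from compound 2 to compound 3 (0.42 log units; beyond the scatter) exchanges 1-(aminomethyl)ethyl for 2-acetamidoethyl and is modest. The change to compound 4 removes the acetamido again but leaves a hydroxy rather than an amine. In this assay a step no larger than modest is expected, if anything toward a lower number. Compound 4 is estimated at 40000 nM, between 12000 nM and 130000 nM. This estimate means an expected step of a 1.7-fold lower number from compound 3 to compound 4 (0.22 log units; within the scatter).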

Compound 4, half-maximal cytotoxic concentration: > 100000 nM
Compound 4 ended at the assay's limit; the forecaster's own chance of this, stated with the estimate: 25%; at least 2.5-fold (0.39 log units) between middle value and limit.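

With (2-hydroxyethyl)amino at this place, compound 4 reaches only a limit of this assay and gives no plain number: the limit of > 100000 nM in this assay, at which 1 of the 4 values shown sits.

Hydroxy in place of acetamido gives an at least 1.5-fold higher number from compound 3 to compound 4 (0.18 log units; that floor lies within the scatter) and so shows no fall in the number, although the true size of the step stays unknown. The comparison with the branched amine chain is clearer, with an at least 4.0-fold higher number from compound 2 to compound 4 (0.60 log units; beyond the scatter), which places the 2-hydroxyethyl chain on the side of lower toxicity in this test.

As far as these compounds go, the steps from compound 1 cannot be read, so how its unbranched amine chain compares with the chains of the other compounds stays open. Also open, from the compounds shown here alone, is whether a carboxylic acid or a methoxy group at the chain end, or a longer chain carrying hydroxy, would keep the number this high.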